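A few compounds are considered here, and "the series" means these few. Any claim that something is new, unique, unknown or untested is made for them only; others in the source may bear on it.

Compound 1 `COc1ccc(-n2nc(C(=O)Nc3cccc(F)c3)nc2-c2cc(OC)c(OC)c(OC)c2)cc1`: 72%
Compound 2 `COc1ccc(-n2nc(C(=O)Nc3ccc(C(F)(F)F)cc3)nc2-c2cc(OC)c(OC)c(OC)c2)cc1`: 65%
Compound 3 `COc1ccc(-n2nc(C(=O)Nc3ccc(C(=O)O)cc3)nc2-c2cc(OC)c(OC)c(OC)c2)cc1`: 74%

In a functional assay on the whole organism for inhibition, with Rattus norvegicus as the target, read by paw edema, with stated times of 30 min and 3 h, at a dose of 0.28 mmol/kg by the oral route (a lower number here means less inhibition, a higher number more inhibition at the dose given (going by the name of the read-out)), compound 3 sits at the top of these three numbers, though its separation from the others is small: a number 2 percentage points higher from compound 1 to compound 3 (within the scatter) and a number 9 percentage points higher from compound 2 to compound 3 (within the scatter). Compound 4 `COc1ccc(-n2nc(C(=O)Nc3ccccc3)nc2-c2cc(OC)c(OC)c(OC)c2)cc1` has not been measured. It differs from compound 3 by hydrogen in place of carboxy on an aromatic carbon. The two steps that bear on this change, a number 2 percentage points higher from compound 1 to compound 3 (within the scatter) and a number 9 percentage points higher from compound 2 to compound 3 (within the scatter), show that swapping the group on the amide-type nitrogen among three different aryl groups moved the read-out by amounts within the scatter. Removing the carboxy group is therefore expected to give compound 4 a value close to that of compound 3, with a number 4 percentage points lower from compound 3 to compound 4 (within the scatter) not beyond the scatter. Compound 4 is estimated at 70%, in the range 58% to 82%.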

Compound 4, a percentage reported as inhibition, in the whole organism at one dose (the size of the read-out at that dose, not a potency): 54%
The estimate for compound 4 lay 16 percentage points above the measured number; the measured number lies below the stated range.
By their numbers in this assay, from the lowest: compound 4; then compounds 2, 1 and 3 (each within the scatter of the next).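

In this assay the unsubstituted phenyl group falls short of each substituted ring, with a number 20 percentage points lower from compound 3 to compound 4 (beyond the scatter) and a number 11 percentage points lower from compound 2 to compound 4 (beyond the scatter) and also a number 18 percentage points lower from compound 1 to compound 4 (beyond the scatter) on record. The earlier swaps among substituted rings had stayed within the scatter, so only now does it appear that having a group on this ring counts for more than which of these three groups it is. No measurement given here accounts for the drop. The compounds shown leave open whether an amine or a chlorine atom on this ring would also hold the read-out near that of compound 3.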